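The compounds below may be only part of what the source reports. "The series", "measured", "known", "first", "only" and "open" are said of these compounds alone.

Measured so far:
- compound 1 `CC(C)S(=O)(=O)NC(=O)c1ccc(Nc2nc(NC3(c4ccc(Cl)cc4)CC3)nc(OCC(F)(F)F)n2)cc1`: 31 nm/s
- compound 2 `CC(C)(C)NC(=O)NCCS(=O)(=O)NC(=O)c1ccc(Nc2nc(NC3(c4ccc(Cl)cc4)CC3)nc(OCC(F)(F)F)n2)cc1`: 49 nm/s
- compound 3 `CCS(=O)(=O)NC(=O)c1ccc(Nc2nc(NC3(c4ccc(Cl)cc4)CC3)nc(OCC(F)(F)F)n2)cc1`: 28 nm/s

In a physicochemical assay for permeability, using PAMPA, at pH 7.4 (on this read-out lower numbers stand for lower permeability and higher numbers for higher permeability), compound 1 gives 31 nm/s, the second highest of the three numbers. Its nearest neighbour is compound 3, a 1.1-fold lower number from compound 1 to compound 3 (0.04 log units; within the scatter); the furthest is compound 2, a 1.6-fold higher number from compound 1 to compound 2 (0.20 log units; within the scatter). Neither step leaves the scatter, and the same holds for the remaining pair, a 1.8-fold lower number from compound 2 to compound 3 (0.24 log units; within the scatter), so the three measured compounds are not separated in this read-out.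

Compound 4 `CC(C)OC(=O)NCCS(=O)(=O)NC(=O)c1ccc(Nc2nc(NC3(c4ccc(Cl)cc4)CC3)nc(OCC(F)(F)F)n2)cc1` differs from compound 1 in one place: 2-((isopropoxycarbonyl)amino)ethyl in place of isopropyl on a sulfonyl sulfur. For the measured compounds named here, the step that bears on it most is the one from compound 1 to compound 2, where a chain of comparable length carrying a donor and acceptors also replaced isopropyl on the sulfonyl sulfur and gave a 1.6-fold higher number from compound 1 to compound 2 (0.20 log units; within the scatter). On that basis no step beyond the scatter is expected for compound 4, with a 1.3-fold higher number from compound 1 to compound 4 (0.11 log units; within the scatter) as the estimated change. Compound 4 is therefore expected to give 40 nm/s in this assay, within a range of 20 nm/s to 80 nm/s.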

Compound 4, apparent permeability: 71 nm/s
Compound 4: middle estimate off by 1.8-fold (0.25 log units), on the low side; low and high end bracket the measured number.
By their numbers in this assay, from the lowest: compounds 3, 1, 2 and 4 (each within the scatter of the next, the first and the last beyond it).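

In this assay, for the compounds shown here, 2-((isopropoxycarbonyl)amino)ethyl on the sulfonyl sulfur gives the first steps beyond the scatter, a 2.3-fold higher number from compound 1 to compound 4 (0.36 log units; beyond the scatter) and a 2.5-fold higher number from compound 3 to compound 4 (0.40 log units; beyond the scatter), both modest. The chain end alone does not separate the two longer chains, with isopropoxy in place of (tert-butyl)amino on a carbonyl carbon giving a 1.4-fold higher number from compound 2 to compound 4 (0.16 log units; within the scatter), yet compound 2 goes against any general gain from a longer chain, as a 1.6-fold higher number from compound 1 to compound 2 (0.20 log units; within the scatter) stays within the scatter. No measurement at hand accounts for the difference between these steps.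

The compounds shown leave open how the number responds to the length of the chain, since all the longer chains here have the same two-carbon link. A chain ending in a carboxylic acid or an amine, or a longer alkyl chain on the sulfonyl sulfur, remains to be compared.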